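Adding a methoxy group to the anilide of compound 3

The source may report more compounds than this note shows. Statements on the series, on what has been measured and on what is new or still open speak of the compounds shown alone.

Measured compounds:
- compound 3 `COc1ccc2nc(C)cc(OCC(=O)Nc3cccc(C)c3)c2c1`: 193000 nM
- compound 1 `Cc1cc(C)cc(NC(=O)COc2cc(C)nc3ccc(C)cc23)c1`: 83000 nM
- compound 2 `COc1ccc2nc(C)cc(NC(=O)C(=O)Nc3cc(C)cc(C)c3)c2c1`: 10000 nM

In a physicochemical assay for solubility, in phosphate buffer, measured as kinetic solubility, with a stated time of 1 h, at pH 7.4 (on this read-out lower numbers stand for lower solubility and higher numbers for higher solubility), compound 3 gives the highest of the three numbers, and compound 1 gives a lower number, while compound 2 gives the lowest. Compound 4 `COc1ccc2nc(C)cc(OCC(=O)Nc3cc(C)ccc3OC)c2c1` differs from compound 3 by one change: methoxy in place of hydrogen on an aromatic carbon. Going by the values given here, no measured pair shows this change. The step from compound 3 to compound 4 in this assay is therefore expected to be small, likely a slightly lower number that stays within the scatter, given as a 1.5-fold lower number from compound 3 to compound 4 (0.17 log units; within the scatter). For compound 4 the estimate in this assay is 130000 nM, with a range from 50000 nM to 320000 nM.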

Compound 4, solubility: 9500 nM
Compound 4: middle estimate off by 14-fold (1.14 log units), on the high side; measured number below the stated range.
By their numbers in this assay, from the lowest: compounds 4 and 2 (each within the scatter of the next); then compound 1; then compound 3.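

In this assay, going by these compounds alone, the change from 3-methylphenyl to 2-methoxy-5-methylphenyl gives a 20-fold lower number from compound 3 to compound 4 (1.31 log units; beyond the scatter) and is the first step that differs in one place. It shows that this ring carbon, ortho to a large group and para to a methyl group, is not a neutral place for substitution on this read-out, since a methoxy of only two heavy atoms moves the number this far. Nothing available explains the drop.

From the compounds shown here alone, whether it belongs to methoxy itself or to any group at this carbon stays open. Compounds carrying a hydroxyl, a fluorine or an amine there, or methoxy on another ring carbon, would begin to separate these readings.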